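Amide aryl variation on a shared core

A few compounds are considered here, and "the series" means these few. Any claim that something is new, unique, unknown or untested is made for them only; others in the source may bear on it.

Measured compounds:
compound 1 `O=C(Nc1cccc(-c2oc3cc(-c4ccc(F)cc4)ccc3c(=O)c2O)c1)c1ccc(F)cc1F` — 9640 nM
compound 2 `Cc1cc(C(=O)Nc2cccc(-c3oc4cc(-c5ccc(F)cc5)ccc4c(=O)c3O)c2)ccc1F` — 12100 nM
compound 3 `O=C(Nc1cccc(-c2oc3cc(-c4ccc(F)cc4)ccc3c(=O)c2O)c1)c1cc(F)cc(F)c1` — 7410 nM

Three compounds share a core and differ only in the aryl group attached to the carbonyl carbon of the amide. In a functional assay on GTL 16 cells for antiproliferative activity against GTL 16 cell line (Homo sapiens), read by CCK-8 assay, with a stated time of 72 h (on this read-out lower numbers stand for stronger inhibition and higher numbers for weaker inhibition), compound 1 gives 9640 nM. Compound 1 has the second highest of the three numbers. Its nearest neighbour is found in the step of a 1.3-fold higher number from compound 1 to compound 2 (0.10 log units; within the scatter), and the furthest in the step of a 1.3-fold lower number from compound 1 to compound 3 (0.11 log units; within the scatter). The remaining pair shows a 1.6-fold lower number from compound 2 to compound 3 (0.21 log units; within the scatter). None of these three steps leaves the scatter, so the three aryl groups exchanged so far give no separable numbers.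

Compound 4 `N#Cc1ccc(C(=O)Nc2cccc(-c3oc4cc(-c5ccc(F)cc5)ccc4c(=O)c3O)c2)cc1` is not yet measured. (4-cyanophenyl in place of 2,4-difluorophenyl on a carbonyl carbon). Going by the values given here, no measured step brings in a nitrile, so the three steps bear on this change only by showing that exchanges of the aryl group on the carbonyl carbon have, so far, moved the number no further than the scatter. Compound 4 is therefore expected to stay close to compound 1, with no step beyond the scatter in this assay: the expected step is a 1.0-fold lower number from compound 1 to compound 4 (0.01 log units; within the scatter). The estimate for compound 4 is 9500 nM, with a range from 3500 nM to 26000 nM.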

Compound 4, half-maximal inhibitory concentration: 31800 nM
The estimate for compound 4 lay 3.3-fold (0.52 log units) below the measured number; measured number outside the range, above it.
By their numbers in this assay, from the lowest: compounds 3, 1 and 2 (each within the scatter of the next); then compound 4.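

Going by these compounds alone, the aryl group on the carbonyl carbon is not as indifferent as the earlier exchanges suggested: in this assay, 4-cyanophenyl gives the first steps beyond the scatter, with a 3.3-fold higher number from compound 1 to compound 4 (0.52 log units; beyond the scatter), a 4.3-fold higher number from compound 3 to compound 4 (0.63 log units; beyond the scatter) and a 2.6-fold higher number from compound 2 to compound 4 (0.42 log units; beyond the scatter), all of them modest and all towards weaker inhibition. Compound 4 thus has the highest number of the four and stands apart from the three fluorine-bearing aryl groups, which remain within the scatter of one another, so the change that matters here is the one that removes fluorine and brings in a nitrile, with its single hydrogen-bond acceptor. No measurement is available that explains why this exchange raises the number.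

With only one aryl group lacking fluorine, the compounds shown cannot separate the loss of fluorine from the arrival of the nitrile, and they leave open whether a plain phenyl group would behave like compound 4 or like compound 1. As far as these compounds go, how an amine or a carboxylic acid on this aryl ring would read in this assay also remains open.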